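This account rests on a few compounds, and the source may have more. Where it says the series, first, only, none or still open, it means among the compounds named here.

Measured in an ADME assay on the whole organism (Rattus norvegicus, strain Sprague-Dawley) for metabolic stability, read by LC-MS, with a stated time of 24 h, at a dose of 5 mg/kg by the intravenous route; on this read-out lower numbers stand for a shorter-lived compound and higher numbers for a longer-lived compound:

compound 1 `Cc1ccc(CNC(=O)Nc2ccc(Oc3ncnc4cc(N(C)C)ccc34)cc2)cn1` — 10.5 h
compound 2 `COc1ccc(CNC(=O)Nc2ccc(Oc3ncnc4cc(N(C)C)ccc34)cc2)cc1` — 20.6 h
compound 3 `COc1ccc(CNC(=O)Nc2ccc(Oc3ncnc4cc(N(C)C)ccc34)cc2)cn1` — 1.2 h

Compound 3 stands lowest of the three on this read-out, as an 8.8-fold lower number from compound 1 to compound 3 (0.94 log units; beyond the scatter) and a 17-fold lower number from compound 2 to compound 3 (1.23 log units; beyond the scatter) show, both beyond the scatter. Compound 1 and compound 2 lie within the scatter of each other, as a 2.0-fold higher number from compound 1 to compound 2 (0.29 log units; within the scatter) shows.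

Compound 4 `COc1ccc(NC(=O)Nc2ccc(Oc3ncnc4cc(N(C)C)ccc34)cc2)cc1` is reached from compound 3 by the change (4-methoxyphenyl in place of (6-methoxypyridin-3-yl)methyl on an amide-type nitrogen). Among the measured compounds shown here, two measured steps bear on it. The aryl swap on its own has been seen twice: a 2.0-fold higher number from compound 1 to compound 2 (0.29 log units; within the scatter) was within the scatter, whereas a 17-fold lower number from compound 2 to compound 3 (1.23 log units; beyond the scatter) was large, so the move from compound 3 toward the 4-methoxyphenyl group is expected to run upward, reversing that large step. For the measured compounds named here, the loss of the methylene between the aryl group and the amide-type nitrogen has no measured counterpart; compound 4 and compound 2 differ only in this, and nothing measured says what it does.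

Because of a 17-fold lower number from compound 2 to compound 3 (1.23 log units; beyond the scatter) the step for compound 4 is expected to be an 8.3-fold higher number from compound 3 to compound 4 (0.92 log units; beyond the scatter), upward. Compound 4 is accordingly estimated at 10 h, within a range of 3 h to 35 h. Going by the values given here, the range is wide; the methylene removal has no measured counterpart.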

Compound 4, half-life: 1.6 h
For compound 4 the middle estimate is 6.3-fold (0.80 log units) above the measured one, and the stated range ends above it.
By their numbers in this assay, from the lowest: compounds 3 and 4 (each within the scatter of the next); then compounds 1 and 2 (each within the scatter of the next).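

Among the compounds shown here, the step of a 13-fold lower number from compound 2 to compound 4 (1.11 log units; beyond the scatter) gives the first measured reading in this assay for 4-methoxyphenyl in place of 4-methoxybenzyl on an amide-type nitrogen, and this single change is large. The step of a 6.6-fold lower number from compound 1 to compound 4 (0.82 log units; beyond the scatter), with 4-methoxyphenyl in place of (6-methylpyridin-3-yl)methyl at the same nitrogen, also lies beyond the scatter, though it alters the aryl group as well as the chain. The step of a 1.3-fold higher number from compound 3 to compound 4 (0.12 log units; within the scatter) lies within the scatter, so compound 3 and compound 4 cannot be told apart here, and the pairs from compound 2 show that a half-life in this range is reached by either of two separate changes: 6-methoxypyridin-3-yl in place of 4-methoxyphenyl, or 4-methoxyphenyl in place of 4-methoxybenzyl.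

Open, going by these compounds, is how a longer chain, such as 2-phenylethyl on the amide-type nitrogen, would read on this scale, and whether 6-methoxypyridin-3-yl placed directly on that nitrogen would stay with compound 3 and compound 4. Nothing in the data on hand accounts for any of these steps.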